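Amide aryl variation in a TRPM8 antagonist series

A few compounds are considered here, and "the series" means these few. Any claim that something is new, unique, unknown or untested is made for them only; others in the source may bear on it.

Compound 2 `C[C@H](c1ccc(F)cc1)N(Cc1cccc(C(=O)O)c1)C(=O)c1cc2ccccn2n1` gives the lowest number of the two compounds measured in an assay on CHO T-rex cells for antagonist activity at transient receptor potential cation channel subfamily M member 8 (Homo sapiens), read by calcium flux, with a stated time of 20 min (a higher number here means a weaker inhibitor, a lower number a stronger inhibitor), at 94 nM. Compound 1 `C[C@H](c1ccc(F)cc1)N(Cc1cccc(C(=O)O)c1)C(=O)c1cccc(-c2ccccc2)c1` in this assay gives 837 nM, a gap beyond the scatter. Compound 3 `C[C@H](c1ccc(F)cc1)N(Cc1cccc(C(=O)O)c1)C(=O)c1cc2ccccc2s1` carries a group of 9 heavy atoms (8 carbon, 1 sulfur; one five-membered aromatic ring with 1 hetero atom, one six-membered aromatic ring of carbon only) in place of a group of 9 heavy atoms (7 carbon, 2 nitrogen; one five-membered aromatic ring with 2 hetero atoms, one six-membered aromatic ring with 1 hetero atom), on a carbonyl carbon. Among the measured compounds shown here, no single-change step is available to size this replacement, so the expectation rests on the two values shown. A move toward a higher number is expected, since compound 1 with its carbon-only aromatic at the carbonyl gives 837 nM. For compound 3 a step of a 2.7-fold higher number from compound 2 to compound 3 (0.42 log units; beyond the scatter) is estimated, giving an expected 250 nM with a range of 60 nM to 1000 nM.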

Compound 3, half-maximal inhibitory concentration: 145 nM
For compound 3 the middle estimate is 1.7-fold (0.24 log units) above the measured one, and the stated range covers the measured number.
By their numbers in this assay, from the lowest: compounds 2 and 3 (each within the scatter of the next); then compound 1.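

At the carbonyl carbon, 1-benzothiophen-2-yl can take the place of the group with two nitrogens, and this assay shows a 1.5-fold higher number from compound 2 to compound 3 (0.19 log units; within the scatter) for this swap. Neither nitrogen of the leaving group is therefore needed to reach a number of this size, and a six-membered aromatic ring of carbon only is accepted here, with compound 3 at 145 nM in this pair.

On these data alone, whether benzofuran-2-yl, a single thiophen-2-yl ring, or a fluorine or an amine on the benzothiophene would hold this number remains open. No measurement at hand gives a reason for the result.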